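Replacing a Piperidine with an Anilino Group on One Core

The compounds below may be only part of what the source reports. "The series", "measured", "known", "first", "only" and "open" are said of these compounds alone.

Compound 1 `Cc1ccc(NC2=CC(=O)c3nc4n(c3C2=O)[C@H]2OC[C@@H](O)[C@H]2OC4)cc1C` gives 860 nM in a functional assay on MGC-803 cells (Homo sapiens) for inhibition, read by sulforhodamine B assay; a lower number here means a stronger inhibitor, a higher number a weaker inhibitor.
Compound 2 `O=C1C(N2CCCCC2)=CC(=O)c2c1nc1n2[C@H]2OC[C@@H](O)[C@H]2OC1` gives only a limit, > 4000 nM, in this assay.
Compound 3 `COc1cccc(NC2=CC(=O)c3nc4n(c3C2=O)[C@H]2OC[C@@H](O)[C@H]2OC4)c1` gives 1780 nM in this assay.

Among the three measured compounds, compound 2 stands apart: it sits at the limit of > 4000 nM in this assay, at which 1 of the 3 values shown sits, and so has no number of its own. The two compounds that carry an arylamine on the shared core both give numbers, and the step between them is a 2.1-fold higher number from compound 1 to compound 3 (0.32 log units; beyond the scatter), a modest change for swapping one aryl group for another.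

Compound 4 `O=C1C(Nc2cccc(F)c2)=CC(=O)c2c1nc1n2[C@H]2OC[C@@H](O)[C@H]2OC1` is the piperidine compound reworked into an arylamine: (3-fluorophenyl)amino in place of piperidin-1-yl on a double-bonded ring carbon. For the measured compounds named here, no measured step covers this exact exchange, but compound 4 resembles compounds 1 and 3 in having an arylamine rather than a piperidine. The expectation is therefore a fall in the number, estimated as an at least 2.6-fold lower number from compound 2 to compound 4 (0.42 log units; beyond the scatter). Compound 4 is expected to give about 1500 nM, within a range from 600 nM to 4000 nM.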

Compound 4, half-maximal inhibitory concentration: 1470 nM
Compound 4: the middle estimate sits 1.0-fold (0.01 log units) above what was measured, within the range that was stated.
By their numbers in this assay, from the lowest: compounds 1, 4 and 3 (each within the scatter of the next, the first and the last beyond it). At a limit, above all of these: compound 2.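

In this assay, for the compounds shown here, the direct exchange of piperidin-1-yl for (3-fluorophenyl)amino on the double-bonded ring carbon gives an at least 2.7-fold lower number from compound 2 to compound 4 (0.43 log units; beyond the scatter) and so measures a change that the earlier compounds could only hint at. Compound 4 lies within the scatter of both compound 1 and compound 3, so all three arylamines shown give numbers, whichever aryl group they carry. From the compounds shown here alone, the true size of the step stays unknown, because compound 2 gives a limit and not a number: the limit of > 4000 nM in this assay, at which 1 of the 4 values shown sits.

The swap changes two things at once, bringing in an aromatic ring and an amine hydrogen, and the compounds shown do not tell these apart. A cyclohexylamino group would keep the amine hydrogen without the aromatic ring, while an N-methylanilino group would keep the ring without that hydrogen.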